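Replacing piperidin-4-yl with 4-hydroxyphenyl on a shared core

This account rests on a few compounds, and the source may have more. Where it says the series, first, only, none or still open, it means among the compounds named here.

Compound 1 `COc1ccc(-c2noc(C3CCCN3)n2)cc1OC1CCCC1` gives 212000 nM
Compound 2 `COc1ccc(-c2noc(C3CCNCC3)n2)cc1OC1CCCC1` gives 370 nM
Compound 3 `COc1cc(-c2noc(-c3ccncc3)n2)ccc1OCc1ccccc1` gives > 1000000 nM as a limit

In a functional assay on MDA-MB-231 cells (Homo sapiens) for antiproliferative activity, read by MTT assay, with a stated time of 24 h (on this read-out higher numbers stand for weaker inhibition and lower numbers for stronger inhibition), compound 2 holds the lower of the two actual numbers at 370 nM and compound 1 lies far higher at 212000 nM in the same test. The entry for compound 3 is a limit of the assay and not a number.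

Compound 4 `COc1ccc(-c2noc(-c3ccc(O)cc3)n2)cc1OC1CCCC1` keeps the core of compound 2 and carries 4-hydroxyphenyl in place of piperidin-4-yl on an aromatic carbon. Among the measured compounds shown here, only one measured step swaps a group at this place (a 570-fold lower number from compound 1 to compound 2 (2.76 log units; beyond the scatter)) and it is large and beyond the scatter. A sizeable rise in the number is therefore expected in this assay, meaning weaker inhibition, and the estimated step is large (a 41-fold higher number from compound 2 to compound 4 (1.61 log units; beyond the scatter)). For compound 4 the estimated value is 15000 nM with 800 nM and 250000 nM as the ends of its expected range.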

Compound 4, half-maximal inhibitory concentration: 310 nM
Compound 4: the middle estimate sits 48-fold (1.68 log units) above what was measured, outside the stated range (below it).
By their numbers in this assay, from the lowest: compounds 4 and 2 (each within the scatter of the next); then compound 1. At a limit, above all of these: compound 3.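

In this assay, this place on the shared core takes either of two quite different six-membered rings, with a 1.2-fold lower number from compound 2 to compound 4 (0.08 log units; within the scatter) between non-aromatic piperidin-4-yl and aromatic 4-hydroxyphenyl. A ring nitrogen is therefore not needed here, since 4-hydroxyphenyl has none, and the large gap from pyrrolidin-2-yl remains, with a 680-fold lower number from compound 1 to compound 4 (2.83 log units; beyond the scatter) in the same test. Nothing measured here explains why the two groups read alike.

Still open, going by these compounds, is whether the hydroxyl itself counts, which plain phenyl or 4-methoxyphenyl at this place would show. A carboxylic acid there is also an open case.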